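Cyclohexyl to phenyl on the carbamate nitrogen in salicylanilide carbamates

The source may report more compounds than this note shows. Statements on the series, on what has been measured and on what is new or still open speak of the compounds shown alone.

Measured so far in an ADME assay on HepG2 cells (Homo sapiens), read by MTT assay, with a stated time of 72 h, in the presence of a further agent that is not named here; on this read-out higher numbers stand for weaker inhibition and lower numbers for stronger inhibition:
compound 1, `O=C(NC1CCCCC1)Oc1ccccc1C(=O)Nc1ccccc1`: 51500 nM
compound 2, `O=C(NC1CCCCC1)Oc1ccc(Cl)cc1C(=O)Nc1ccc(Br)cc1`: 9400 nM
compound 3, `O=C(Nc1ccccc1)Oc1ccc(Cl)cc1C(=O)Nc1ccc(Br)cc1`: 5450 nM

Compound 1 gives the highest of the three numbers; compound 2 and compound 3 lie beyond the scatter below it. The difference between the core of compound 1 and the core of compound 2 is not broken down here.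

One change is seen in a measured pair and recurs in an unmeasured one. From compound 2 to compound 3 it reads phenyl in place of cyclohexyl on an amide-type nitrogen and the step is a 1.7-fold lower number from compound 2 to compound 3 (0.24 log units; within the scatter) in this assay. The same change, (phenyl in place of cyclohexyl on an amide-type nitrogen), leads from compound 1 to compound 4, `O=C(Nc1ccccc1)Oc1ccccc1C(=O)Nc1ccccc1`, whose value in this assay is not yet known.

With a single measured example of the change, the expectation for compound 4 rests on compound 2 and compound 3 alone, because a 1.7-fold lower number from compound 2 to compound 3 (0.24 log units; within the scatter) was within the scatter. The step from compound 1 to compound 4 is therefore expected to be small, about a 1.5-fold lower number from compound 1 to compound 4 (0.17 log units; within the scatter). Compound 4 is estimated at 35000 nM, with a likely range from 15000 nM to 80000 nM.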

Compound 4, half-maximal inhibitory concentration: 26800 nM
The estimate for compound 4 lay 1.3-fold (0.12 log units) above the measured number, within the range that was stated.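

In this assay, phenyl in place of cyclohexyl on an amide-type nitrogen gives a 1.9-fold lower number from compound 1 to compound 4 (0.28 log units; within the scatter). Set beside the earlier step, the change reads alike on the two cores, with no difference between them that can be told from the scatter: the same change on two cores in this assay, a 1.7-fold lower number (0.24 log units; within the scatter) from compound 2 to compound 3 and a 1.9-fold lower number (0.28 log units; within the scatter) from compound 1 to compound 4, 1.1-fold (0.05 log units) apart, within the scatter of two such steps. Neither step on its own separates phenyl from cyclohexyl at this nitrogen, and agreement on two cores does not show how the change would behave on any other core in the series.

The compounds shown leave open whether a different group on that nitrogen, such as a longer alkyl chain, a benzyl group or a chain ending in a carboxylic acid, would move the number beyond the scatter. On these data alone, how much the chloro and bromo substituents of compound 2 each contribute to its number also remains open, as does whether either one alone would match the pair of them.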